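A few compounds are considered here, and "the series" means these few. Any claim that something is new, unique, unknown or untested is made for them only; others in the source may bear on it.

In a functional assay on PANC-1 cells (Homo sapiens) for cytotoxicity, read by WST assay, with a stated time of 24 h (a lower number here means a stronger inhibitor, a higher number a weaker inhibitor), compound 1 `O=C(/C=C/CCCCCCc1ccccc1)N1CCCCC1` gives > 100000 nM, which is a limit. Compound 2 `O=C(/C=C/CCCCCCc1ccccc1)N1CCCC1` gives > 100000 nM, also a limit, so it has no exact number. Compound 3 `O=C(/C=C/CCCCCCc1ccccc1)N1CCCCCC1` carries azepan-1-yl in place of pyrrolidin-1-yl on a carbonyl carbon, azepan-1-yl in place of pyrrolidin-1-yl on a carbonyl carbon. Going by the values given here, the only measured step bearing on this is a step that the two limits leave unreadable from compound 1 to compound 2, and it has no readable size. Both measured compounds, compound 1 and compound 2, sit at the limit of > 100000 nM in this assay, at which 2 of the 2 values shown sit, so no change beyond the scatter is expected, and the estimated step is a step that the limit leaves unreadable from compound 2 to compound 3. For compound 3 the expected value is 120000 nM, with an estimated range of 50000 nM to 300000 nM.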

Compound 3, half-maximal inhibitory concentration: > 100000 nM
Compound 3 ended at the assay's limit; the forecaster's own chance of this, stated with the estimate: 85%; the middle value is on the limit's open side.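

No step can be read among compound 1, compound 2 and compound 3, as all three values are limits: the limit of > 100000 nM in this assay, at which 3 of the 3 values shown sit.

Going by these compounds, whether piperidin-1-yl, pyrrolidin-1-yl and azepan-1-yl differ at all in this assay stays open.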